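Ethoxy in Place of Fluoro on a Limit-Bound Compound

A few compounds are considered here, and "the series" means these few. Any claim that something is new, unique, unknown or untested is made for them only; others in the source may bear on it.

Compound 3 `COc1cc(-n2ncnc2-c2cccc(F)c2)cc(OC)c1OC` carries a 3-fluorophenyl group on the shared core. In a functional assay on MCF7 cells (Homo sapiens) for antiproliferative activity, read by MTT assay, with a stated time of 72 h (on this read-out lower numbers stand for stronger inhibition and higher numbers for weaker inhibition), compound 3 gives > 10000 nM, which is a limit of the assay rather than a number. Compound 1 `COc1ccccc1-c1ncnn1-c1cc(OC)c(OC)c(OC)c1`, bearing a 2-methoxyphenyl group, gives > 10000 nM in this assay, again a limit. Compound 2 `COc1cc(-n2ncnc2-c2ccc(C)cc2)cc(OC)c1OC`, bearing a 4-methylphenyl group, gives 540 nM in this assay. The readable steps are an at least 18-fold lower number from compound 1 to compound 2 (1.26 log units; beyond the scatter) and an at least 18-fold higher number from compound 2 to compound 3 (1.26 log units; beyond the scatter), whereas a step that the two limits leave unreadable from compound 1 to compound 3. Two of the three values sit at the limit of > 10000 nM in this assay, at which 2 of the 3 values shown sit.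

Compound 4 `CCOc1cccc(-c2ncnn2-c2cc(OC)c(OC)c(OC)c2)c1` differs from compound 3 by ethoxy in place of fluoro on an aromatic carbon. Going by the values given here, no measured step exchanges fluoro for an alkoxy group on this ring, and the only compound carrying an alkoxy group on it, compound 1, stands at the limit. He therefore expects compound 4 to stay at or close to the limit in this assay, with an estimate of 10000 nM spanning 2500 nM to 30000 nM. The step from compound 3 is expected to be a number no higher from compound 3 to compound 4 (the limit leaves the size open).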

Compound 4, half-maximal inhibitory concentration: > 10000 nM
Compound 4: no number, only a limit; the forecaster's own chance of this, stated with the estimate: 60%; the middle value sits exactly at the limit.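

In this assay compound 4 gives > 10000 nM, a limit of the assay and not a number. Going by these compounds alone, compound 3 also stands at a limit, so no step between compound 3 and compound 4 can be read. Whether ethoxy in place of fluoro changes the read-out at all stays open, with most values resting on one limit: the limit of > 10000 nM in this assay, at which 3 of the 4 values shown sit.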